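Isopropyl in Place of Methyl on the Amide Nitrogen

A few compounds are considered here, and "the series" means these few. Any claim that something is new, unique, unknown or untested is made for them only; others in the source may bear on it.

Measured compounds:
compound 1: `CNC(=O)c1cccc(NC(=O)N2CCC(Oc3ccccc3Cl)CC2)c1` — < 4 nM
compound 2: `CNC(=O)c1cccc(NC(=O)N2CCC(Oc3ccc(F)cc3Cl)CC2)c1` — 6 nM

Of the compounds shown here, two have been measured in an assay on isolated protein for inhibition of acyl-CoA desaturase 1 (Mus musculus); on this read-out lower numbers stand for stronger inhibition and higher numbers for weaker inhibition. Compound 1 `CNC(=O)c1cccc(NC(=O)N2CCC(Oc3ccccc3Cl)CC2)c1` gives < 4 nM, and that figure is a limit of the assay rather than a number. Compound 2 `CNC(=O)c1cccc(NC(=O)N2CCC(Oc3ccc(F)cc3Cl)CC2)c1` gives 6 nM. The only measured step, an at least 1.5-fold higher number from compound 1 to compound 2 (0.17 log units; that floor lies within the scatter), concerns a fluoro in place of hydrogen on an aromatic carbon; that compound 1 sits at a limit is shown by the limit of < 4 nM in this assay, at which 1 of the 2 values shown sits.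

Compound 3 `CC(C)NC(=O)c1cccc(NC(=O)N2CCC(Oc3ccccc3Cl)CC2)c1` has not yet been measured. It differs from compound 1 by isopropyl in place of methyl on an amide-type nitrogen. Within the data shown here, no measured step touches this part of the molecule: the single recorded step alters the aromatic ring and says nothing about the amide nitrogen. Going by these compounds, all that is known is that compound 1 stands at the limit of this assay, so its true strength remains open.

Among the measured compounds shown here, with no step to lean on, compound 3 is expected to give 8 nM, roughly between 2 nM and 40 nM. This estimate means an at least 2.0-fold higher number from compound 1 to compound 3 (0.30 log units; that floor lies within the scatter), a step without any measured counterpart.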

Compound 3, half-maximal inhibitory concentration: 810 nM
Compound 3: the middle estimate sits 100-fold (2.01 log units) below what was measured, and the stated range ends below it.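

The amide nitrogen proves to be a highly sensitive position: in this assay, putting isopropyl in place of methyl there gives an at least 200-fold higher number from compound 1 to compound 3 (2.30 log units; beyond the scatter). The earlier step, on the aromatic ring, has a floor that lies within the scatter, whereas this one lies beyond it, so the amide nitrogen is the first place shown where a single change costs a large part of the strength. Compound 1 gives < 4 nM, which is a limit of the assay and not a number, so the size of this step is only a floor: the limit of < 4 nM in this assay, at which 1 of the 3 values shown sits.

The compounds shown leave open whether an ethyl or a cyclopropyl group on the amide nitrogen would keep the strength of compound 1 or lose it as isopropyl does, and how an amide with no carbon group on that nitrogen would compare. They also give no reason for the loss, and the isopropyl change appears only on the core of compound 1, so its cost alongside the fluoro group of compound 2 remains unknown.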